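The compounds below may be only part of what the source reports. "The series", "measured", "known", "first", "only" and "open" are said of these compounds alone.

Compound 1 `CC(=O)c1nc([N+](=O)[O-])c(Sc2cccc(Cl)c2Cl)s1`, compound 2 `CC(=O)c1nc([N+](=O)[O-])c(Sc2c(Cl)cncc2Cl)s1` and compound 3 `CC(O)c1nc([N+](=O)[O-])c(Sc2c(Cl)cncc2Cl)s1` were tested in a functional assay on HCT-116 cells (Homo sapiens) for antiproliferative activity, read by MTT assay, with a stated time of 72 h; a higher number here means a weaker inhibitor, a lower number a stronger inhibitor. Compound 1 gives 9290 nM, compound 2 gives 8450 nM and compound 3 gives 18600 nM. Compound 2 has the lowest of the three numbers, though its gap to compound 1 lies within the scatter, so the two cannot be ranked; compound 3 stands apart, with a 2.2-fold higher number from compound 2 to compound 3 (0.34 log units; beyond the scatter).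

Compound 4 `O=C(NCc1ccc(F)cc1)c1nc([N+](=O)[O-])c(Sc2c(Cl)cncc2Cl)s1` has not yet been measured. It differs from compound 2 in one place: (4-fluorobenzyl)amino in place of methyl on a carbonyl carbon. Among the compounds with values here, the only measured step that touches this region is the one from compound 2 to compound 3, where swapping the acetyl for 1-hydroxyethyl gave a modest shift. Within the data shown here, no measured pair shows what a large (4-fluorobenzyl)amino group on this carbonyl carbon does, so the direction is open. Compound 4 is therefore expected to land near compound 2, with a 1.2-fold lower number from compound 2 to compound 4 (0.08 log units; within the scatter), and the estimate for compound 4 is 7000 nM, in a wide range from 1500 nM to 30000 nM.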

Compound 4, half-maximal inhibitory concentration: 11200 nM
Compound 4: middle estimate off by 1.6-fold (0.20 log units), on the low side; low and high end bracket the measured number.
By their numbers in this assay, from the lowest: compounds 2, 1, 4 and 3 (each within the scatter of the next, the first and the last beyond it).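

In this assay, the carbonyl carbon accepts a far larger group with no shift that stands clear of the scatter: (4-fluorobenzyl)amino in place of methyl, which adds a six-membered aromatic ring and a hydrogen-bond donor, gives a 1.3-fold higher number from compound 2 to compound 4 (0.12 log units; within the scatter) in this series. The earlier step, a 2.2-fold higher number from compound 2 to compound 3 (0.34 log units; beyond the scatter), changed the carbonyl itself, whereas this one keeps the carbonyl and shows that the methyl on it can give way to a much bigger group without a readable change in the number. No measurement here accounts for this result.

The compounds shown do not separate the contributions of the amide hydrogen, the benzyl part and the fluorine, so a plain benzyl ketone or an unsubstituted benzylamide could tell these apart. As far as these compounds go, it also remains open how a carboxylic acid or a longer alkyl chain at this carbonyl carbon would behave.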